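The compounds below may be only part of what the source reports. "The series", "measured", "known", "first", "only" and "open" are said of these compounds alone.

Measured so far in an assay on HEK293 cells for displacement of a labelled ligand from P2Y purinoceptor 1 (Homo sapiens), read by scintillation counting, with a stated time of 1 h; on this read-out higher numbers stand for weaker inhibition and lower numbers for stronger inhibition:

compound 1 `CC(C)(C)CN1CCc2c(cccc2Oc2ncccc2NC(=O)Nc2ccc(OC(F)(F)F)cc2)C1` — 11 nM
compound 2 `CCN1CCc2c(cccc2Oc2ncccc2NC(=O)Nc2ccc(OC(F)(F)F)cc2)C1` — 1700 nM
compound 3 `O=C(Nc1ccc(OC(F)(F)F)cc1)Nc1cccnc1Oc1cccc2c1CCNC2` — 3000 nM

Compound 1 holds the lowest number of the three. Its nearest neighbour is compound 2, at a 150-fold higher number from compound 1 to compound 2 (2.19 log units; beyond the scatter); compound 3 lies furthest, at a 270-fold higher number from compound 1 to compound 3 (2.44 log units; beyond the scatter). Between compound 2 and compound 3 the gap is only a 1.8-fold higher number from compound 2 to compound 3 (0.25 log units; within the scatter). Within this small set, the number therefore moves sharply with the substituent on the amine nitrogen in the ring, and the neopentyl group of compound 1 is the only one so far that gives a low number.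

Compound 4 `CC(C)(C)CCN1CCc2c(cccc2Oc2ncccc2NC(=O)Nc2ccc(OC(F)(F)F)cc2)C1` is not yet measured. Compared with compound 1 the change is neopentyl in place of tert-butyl on a saturated chain carbon bound to an amine nitrogen in a ring; read one bond further out, it is neopentyl to 3,3-dimethylbutyl on the ring nitrogen. The two steps that bear on it, from compound 1 to compound 2 and from compound 1 to compound 3, both remove bulk from the nitrogen substituent and both are large losses. Within the data shown here, compound 4 keeps the bulk and adds to the chain, a direction for which no measured step exists. The expectation is therefore retention of the low number, with a possible modest shift in either direction. For compound 4 the expected step is a 1.8-fold higher number from compound 1 to compound 4 (0.26 log units; within the scatter). Compound 4 is estimated at 20 nM, range 5 nM to 90 nM.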

Compound 4, inhibition constant: 190 nM
Compound 4: the middle estimate sits 9.5-fold (0.98 log units) below what was measured; the measured number lies above the stated range.
By their numbers in this assay, from the lowest: compound 1; then compound 4; then compounds 2 and 3 (each within the scatter of the next).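

In this assay, going from neopentyl to 3,3-dimethylbutyl on the ring nitrogen gives a 17-fold higher number from compound 1 to compound 4 (1.24 log units; beyond the scatter), so keeping the tert-butyl group does not by itself keep the low number of compound 1, and how far along the chain the tert-butyl stands also counts. The tert-butyl group still contributes at its new place, with an 8.9-fold lower number from compound 2 to compound 4 (0.95 log units; beyond the scatter), and the whole 3,3-dimethylbutyl group in place of hydrogen gives a 16-fold lower number from compound 3 to compound 4 (1.20 log units; beyond the scatter), yet compound 4 goes against any reading that more carbon on this nitrogen always lowers the number, since it carries the largest substituent of the set and does not hold the lowest number. No data at hand account for this dependence on chain length.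

The compounds shown leave open whether isobutyl or cyclohexylmethyl on the ring nitrogen would come closer to neopentyl or to 3,3-dimethylbutyl. Also open, from the compounds shown here alone, is how a longer chain ending in tert-butyl, or a hydroxyl or an amine on the neopentyl group, would read in this assay.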